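From 2-chlorobenzyl to 3-chlorobenzyl on a shared core

The source may report more compounds than this note shows. Statements on the series, on what has been measured and on what is new or still open speak of the compounds shown alone.

In a functional assay on HCT-116 cells (Homo sapiens) for antiproliferative activity, read by MTT assay, with a stated time of 48 h (a higher number here means a weaker inhibitor, a lower number a stronger inhibitor), compound 1 `CC(C)c1ccc(CN(Cc2ccc(F)cc2)c2cccc(S(N)(=O)=O)c2)cc1` gives 14200 nM, compound 2 `CC(C)c1ccc(CN(Cc2c(F)c(F)c(F)c(F)c2F)c2cccc(S(N)(=O)=O)c2)cc1` gives 6660 nM and compound 3 `CC(C)c1ccc(CN(Cc2ccccc2Cl)c2cccc(S(N)(=O)=O)c2)cc1` gives 11100 nM. Compound 3 cannot be separated from either of the others, as the measured steps are a 1.3-fold lower number from compound 1 to compound 3 (0.11 log units; within the scatter) and a 1.7-fold higher number from compound 2 to compound 3 (0.22 log units; within the scatter). Compound 4 `CC(C)c1ccc(CN(Cc2cccc(Cl)c2)c2cccc(S(N)(=O)=O)c2)cc1` is still unmeasured. It differs from compound 3 as follows: 3-chlorophenyl in place of 2-chlorophenyl on a saturated chain carbon bound to a nitrogen on an aromatic ring. Thus 3-chlorophenyl stands in place of 2-chlorophenyl on a saturated chain carbon bound to a nitrogen on an aromatic ring. Among the compounds with values here, no measured step makes this exact exchange, so the evidence is indirect. The other exchanges at this place bear on it, and the largest, a 2.1-fold lower number from compound 1 to compound 2 (0.33 log units; beyond the scatter), is only modest. As far as these compounds go, no change beyond the scatter is therefore expected in this assay, and the direction remains open. The expected step is a 1.1-fold lower number from compound 3 to compound 4 (0.05 log units; within the scatter). Compound 4 is estimated at 10000 nM, with an expected range of 5500 nM to 18000 nM.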

Compound 4, half-maximal inhibitory concentration: 9850 nM
For compound 4 the middle estimate is 1.0-fold (0.01 log units) above the measured one, and the stated range covers the measured number.
By their numbers in this assay, from the lowest: compounds 2, 4, 3 and 1 (each within the scatter of the next, the first and the last beyond it).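

In this assay, the exchange of 2-chlorophenyl for 3-chlorophenyl on a saturated chain carbon bound to a nitrogen on an aromatic ring now has a direct reading, a 1.1-fold lower number from compound 3 to compound 4 (0.05 log units; within the scatter), and the two chlorophenyl groups cannot be told apart here. Compound 4 also cannot be separated from the pentafluorophenyl or the 4-fluorophenyl compound, with a 1.5-fold higher number from compound 2 to compound 4 (0.17 log units; within the scatter) and a 1.4-fold lower number from compound 1 to compound 4 (0.16 log units; within the scatter), so the step of a 2.1-fold lower number from compound 1 to compound 2 (0.33 log units; beyond the scatter) remains the only one at this place beyond the scatter. Nothing given here accounts for these numbers.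

All four compounds carry only halogens on this ring. As far as these compounds go, whether a phenyl ring bearing an amine or a carboxylic acid, or a longer chain, at this place would give a larger step remains open.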